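Replacing an isoindoline ether with benzyl: expected potency

A few compounds are considered here, and "the series" means these few. Any claim that something is new, unique, unknown or untested is made for them only; others in the source may bear on it.

Measured so far:
Compound 1 `Nc1cc(Cc2ccn(Cc3cccc(-c4ccccc4)c3)n2)c2nn[nH]c2n1`: 55 nM
Compound 2 `Nc1cc(Cc2ccn(Cc3cccc(Oc4cccc5c4CNC5)c3)n2)c2nn[nH]c2n1`: 26 nM

Both compounds were tested in an assay on isolated protein for inhibition of Myeloperoxidase (Homo sapiens), with a stated time of 10 min; on this read-out higher numbers stand for weaker inhibition and lower numbers for stronger inhibition. Compound 2 has the lowest number of the two, with compound 1 standing a 2.1-fold lower number from compound 1 to compound 2 (0.33 log units; beyond the scatter) apart. Within the data shown here, that one step, which exchanged a group of 6 heavy atoms for a group of 10 heavy atoms on an aromatic carbon, is the only measured step and it is modest.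

Compound 3 `Nc1cc(Cc2ccn(Cc3cccc(Cc4ccccc4)c3)n2)c2nn[nH]c2n1` is not yet measured. It differs from compound 2 by a group of 7 heavy atoms (7 carbon; one six-membered aromatic ring of carbon only) in place of a group of 10 heavy atoms (8 carbon, 1 nitrogen, 1 oxygen; one five-membered non-aromatic ring with 1 hetero atom, one six-membered aromatic ring of carbon only), on an aromatic carbon.

The entering benzyl resembles the group of compound 1 more closely than the group that leaves, so the expected change is roughly the reverse of the step from compound 1 to compound 2: a small rise in the number, estimated as a 1.9-fold higher number from compound 2 to compound 3 (0.28 log units; within the scatter). For compound 3 the estimate in this assay is 50 nM, within a range from 20 nM to 130 nM.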

Compound 3, half-maximal inhibitory concentration: 39 nM
Estimate against measurement, compound 3: 1.3-fold (0.11 log units) above; low and high end bracket the measured number.
By their numbers in this assay, from the lowest: compounds 2, 3 and 1 (each within the scatter of the next, the first and the last beyond it).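

At this position, on an aromatic carbon, in this assay the swap to benzyl gives a 1.5-fold higher number from compound 2 to compound 3 (0.18 log units; within the scatter) even though benzyl has no hydrogen-bond donors or acceptors and the group it replaces has both, so those atoms and the non-aromatic ring are not needed to keep the number in this range. Adding the single carbon that turns phenyl into benzyl gives a 1.4-fold lower number from compound 1 to compound 3 (0.15 log units; within the scatter) and so also leaves the number within the scatter, which places benzyl between two groups that differ from each other beyond the scatter without separating it from either. No evidence is available to explain these numbers.

Going by these compounds, what remains open is how far the outer ring can move, for instance on a longer chain such as phenylethyl. Also open, on these data alone, is how an amine or a carboxylic acid on that ring would read in this assay as a test of whether this tolerance extends to such groups.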